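Removing the acetyl from compound 2

The compounds below may be only part of what the source reports. "The series", "measured", "known", "first", "only" and "open" are said of these compounds alone.

Among the compounds with values here, in a functional assay on LNCaP cells (Homo sapiens) for antiproliferative activity, read by ATP content, with a stated time of 48 h (a lower number here means a stronger inhibitor, a higher number a weaker inhibitor), compound 2 (`CC(=O)Oc1cc(/C=C/c2ccc([N+](=O)[O-])o2)nc2c(O)cccc12`) gives 1610 nM and so holds the higher of the two numbers measured so far. The lower number belongs to compound 1 (`O=[N+]([O-])c1ccc(/C=C/c2ccc3cccc(O)c3n2)o1`), which gives 350 nM in the same read-out. Compound 3 (`O=[N+]([O-])c1ccc(/C=C/c2cc(O)c3cccc(O)c3n2)o1`) differs from compound 2 by hydrogen in place of acetyl on an oxygen on an aromatic ring. Within the data shown here, only one measured step bears on this change: acetoxy in place of hydrogen on an aromatic carbon, which gave a 4.6-fold higher number from compound 1 to compound 2 (0.66 log units; beyond the scatter) and counts as modest. Among the measured compounds shown here, compound 3 keeps an oxygen at that place, so it is not a return to compound 1, and no measured compound carries hydroxy there. What is expected in this assay is a 2.0-fold lower number from compound 2 to compound 3 (0.30 log units; within the scatter) as a modest drop that undoes part of that step. Compound 3 is estimated at 800 nM (range 250 nM to 2500 nM).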

Compound 3, half-maximal inhibitory concentration: 5690 nM
Estimate against measurement, compound 3: 7.1-fold (0.85 log units) below, outside the stated range (above it).
By their numbers in this assay, from the lowest: compound 1; then compound 2; then compound 3.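

In this assay, removing the acetyl does not bring the number back toward that of compound 1 but moves it further away (a 3.5-fold higher number from compound 2 to compound 3 (0.55 log units; beyond the scatter)). Hydroxy at this place therefore costs more than acetoxy does when each is set against hydrogen, the large change (a 16-fold higher number from compound 1 to compound 3 (1.21 log units; beyond the scatter)) exceeding the modest one (a 4.6-fold higher number from compound 1 to compound 2 (0.66 log units; beyond the scatter)). No accompanying evidence accounts for this order of the three compounds.

The compounds shown leave open whether the higher numbers follow any oxygen-bearing group at this place or only these two groups, and a methoxy group, an amine or a fluorine there would test that. They also leave open whether a longer ester than the acetyl would fall nearer compound 1 or nearer compound 3.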